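A few compounds are considered here, and "the series" means these few. Any claim that something is new, unique, unknown or untested is made for them only; others in the source may bear on it.

Three compounds with the same core share a cytotoxicity read-out in an ADME assay on HEK293 cells (Homo sapiens) for cytotoxicity, read by CCK-8 assay, with a stated time of 4 days; a lower number here means a stronger inhibitor, a higher number a weaker inhibitor. Compound 1 `Oc1ccc(-c2cc(-c3cccc(O)c3)nc(-c3cccc(O)c3)c2)cc1` gives 730 nM. Compound 2 `Oc1ccccc1-c1cc(-c2ccccc2O)nc(-c2ccccc2O)c1` gives 140 nM. Compound 3 `Oc1cccc(-c2cc(-c3ccccc3O)cc(-c3cccc(O)c3)n2)c1` gives 130 nM. Compound 2 and compound 3 sit within the usual scatter of each other, and the difference between their two cores is not broken down here. From compound 3 to compound 1 the change is 4-hydroxyphenyl in place of 2-hydroxyphenyl on an aromatic carbon, and the step is a 5.6-fold higher number from compound 3 to compound 1 (0.75 log units; beyond the scatter). Compound 4 `Oc1ccc(-c2cc(-c3ccccc3O)cc(-c3ccccc3O)n2)cc1` is not yet measured; it arises from compound 2 by 4-hydroxyphenyl in place of 2-hydroxyphenyl on an aromatic carbon, the same kind of change, though here the place is next to the ring nitrogen and meta to two 2-hydroxyphenyl groups rather than opposite the ring nitrogen and meta to two 3-hydroxyphenyl groups. Resting on the measured step of a 5.6-fold higher number from compound 3 to compound 1 (0.75 log units; beyond the scatter), compound 4 is expected to show a step of a 3.6-fold higher number from compound 2 to compound 4 (0.55 log units; beyond the scatter) in this assay. The estimate for compound 4 is therefore 500 nM, between 200 nM and 1500 nM.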

Compound 4, half-maximal inhibitory concentration: 6990 nM
Beside the measured number, compound 4's estimate is 14-fold (1.15 log units) below it; the measured number lies above the stated range.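

On the core of compound 2, putting 4-hydroxyphenyl in place of 2-hydroxyphenyl gives a 50-fold higher number from compound 2 to compound 4 (1.70 log units; beyond the scatter) in this assay. The number rises on both cores, but the size of the rise does not carry over from one core to the other: the same change on two cores in this assay, a 5.6-fold higher number (0.75 log units; beyond the scatter) from compound 3 to compound 1 and a 50-fold higher number (1.70 log units; beyond the scatter) from compound 2 to compound 4, 8.9-fold (0.95 log units) apart, beyond the scatter of two such steps. With only these two pairs, this shows that the size of the step cannot simply be transferred between cores in this series, but it does not show what about the core or the place sets that size.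

All the compounds shown carry only hydroxyphenyl groups. From the compounds shown here alone, whether a methoxyphenyl or aminophenyl group in the same place would give a similarly uneven step remains open.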